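A few compounds are considered here, and "the series" means these few. Any claim that something is new, unique, unknown or untested is made for them only; others in the source may bear on it.

Measured in a functional assay on K562 cells (Homo sapiens) for antiproliferative activity, read by MTT assay, with a stated time of 24 h; on this read-out lower numbers stand for stronger inhibition and higher numbers for weaker inhibition:
- compound 1 `COc1cc(OC)c(OC)cc1/C=C/C(=O)c1ccc(OC)c2c1OC(C)(C)C=C2`: > 10000 nM
- compound 2 `COc1ccc(C(=O)/C=C/c2cccc(F)c2)c2c1C=CC(C)(C)O2`: > 10000 nM
- compound 3 `COc1ccc(C(=O)/C=C/c2ccc(C(F)(F)F)cc2)c2c1C=CC(C)(C)O2`: > 10000 nM

Each of these entries is a limit of the assay and not a number. Among the compounds with values here, the series so far is summed up by the limit of > 10000 nM in this assay, at which 3 of the 3 values shown sit.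

In this assay compound 2 gives > 10000 nM, which is a limit. The two other measured compounds offer no number to rank it against.

Next in the series is compound 4 `COc1ccc(/C=C/C(=O)c2ccc(OC)c3c2OC(C)(C)C=C3)cn1`, which carries 6-methoxypyridin-3-yl in place of 3-fluorophenyl on a double-bonded chain carbon bound to a double-bonded chain carbon. The shared core stays as it is.

Within the data shown here, no step between measured compounds is available to size this change. The expectation therefore rests on (the limit of > 10000 nM in this assay, at which 3 of the 3 values shown sit), and no step beyond the scatter is expected, with a reading at the limit again the likeliest result. The expected change is a number no higher from compound 2 to compound 4 (the limit leaves the size open). For compound 4 the estimated value is 10000 nM, with an expected range of 4000 nM to 25000 nM.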

Compound 4, half-maximal inhibitory concentration: > 10000 nM
Compound 4 gave a limit, no number (the forecaster's own chance of this, stated with the estimate: 80%); the middle value sits exactly at the limit.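

The step from compound 2 to compound 4 cannot be read: both entries in this assay are limits of the assay, not numbers. The compounds shown leave open whether any group exchanged on the shared core changes the antiproliferative activity, since all readings rest on one value: the limit of > 10000 nM in this assay, at which 4 of the 4 values shown sit.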